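The source may report more compounds than this note shows. Statements on the series, on what has been measured and on what is new or still open speak of the compounds shown alone.

Compound 1 `C=CC1=C(C(=O)NCc2ccccc2)C(c2ccc(OC)cc2)OC1` gives > 100000 nM in a functional assay on A549 cells (Homo sapiens) for cytotoxicity, read by MTT assay, with a stated time of 24 h (a lower number here means a stronger inhibitor, a higher number a weaker inhibitor), which is a limit of the assay rather than a number.
Compound 2 `C=CC1=C(C(=O)O)C(c2ccc(F)cc2)OC1` gives > 100000 nM in this assay, again a limit.
Compound 3 `C=CC1=C(C(=O)NCc2ccccc2F)C(c2ccc(F)cc2)OC1` gives > 100000 nM in this assay, also a limit.

Within the data shown here, compound 3 therefore stands at the limit and nowhere else: for it only a limit is known, and the two further values known are limits as well, so no compound of this set has a measured number and no order among them can be read. The whole picture is the limit of > 100000 nM in this assay, at which 3 of the 3 values shown sit.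

Compound 4 `C=CC1=C(C(=O)Nc2ccccc2)C(c2ccc(F)cc2)OC1` differs from compound 3 in one place: phenyl in place of 2-fluorobenzyl on an amide-type nitrogen. Among the measured compounds shown here, no step between two measured compounds is known, so the size of such a change cannot be read from a measured pair. Since compound 3 sits at a limit, the expectation is that compound 4 also gives no number in this assay, or at most a weak one, and that any change lies within the scatter. The step is estimated as a step that the limit leaves unreadable from compound 3 to compound 4. Compound 4 is estimated at 150000 nM, with a range from 50000 nM to 500000 nM.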

Compound 4, half-maximal inhibitory concentration: > 100000 nM
Compound 4: a limit, no number; the forecaster's own chance of this, stated with the estimate: 80%; the middle value is on the limit's open side.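

Compound 4 gives a limit of the assay and not a number, so the steps to compound 4 from compound 2 and from compound 3 cannot be read: the limit of > 100000 nM in this assay, at which 4 of the 4 values shown sit.

The compounds shown leave open whether any change on the shared core would give a measured number in this assay, and how large its effect would be.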